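Methoxyphenyl amide chromones: moving the methoxy group

The source may report more compounds than this note shows. Statements on the series, on what has been measured and on what is new or still open speak of the compounds shown alone.

Measured compounds:
compound 1 `COc1cccc(C(=O)Nc2cccc(-c3cc(=O)c4c(OC)c(OC)c(OC)cc4o3)c2)c1` with 7670 nM
compound 2 `COc1ccccc1C(=O)Nc1cccc(-c2cc(=O)c3c(OC)c(OC)c(OC)cc3o2)c1` with 15300 nM
compound 3 `COc1cccc(C(=O)Nc2cccc(-c3cc(=O)c4c(O)c(OC)c(OC)cc4o3)c2)c1` with 35600 nM

The three compounds were measured in a functional assay on MCF7 cells (Homo sapiens) for inhibition, read by MTT assay; a higher number here means a weaker inhibitor of growth, a lower number a stronger inhibitor of growth. Compound 1 is the reference point. Compound 2 differs from it by 2-methoxyphenyl in place of 3-methoxyphenyl on a carbonyl carbon, and the step is a 2.0-fold higher number from compound 1 to compound 2 (0.30 log units; within the scatter). Compound 3 differs from compound 1 by hydrogen in place of methyl on an oxygen on an aromatic ring, and here the step is a 4.6-fold higher number from compound 1 to compound 3 (0.67 log units; beyond the scatter). Compound 3 gives the highest number of the three, and its distance from compound 2 is beyond the scatter, as is its distance from compound 1.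

Compound 4 `COc1ccccc1C(=O)Nc1cccc(-c2cc(=O)c3c(O)c(OC)c(OC)cc3o2)c1` has not yet been measured. It differs from compound 3 by 2-methoxyphenyl in place of 3-methoxyphenyl on a carbonyl carbon. This is the same change as the one from compound 1 to compound 2, made on the core of compound 3 rather than that of compound 1; the two place descriptions are identical, so the change is the same, and the two cores differ by the methoxy to hydroxy exchange described above.

Among the compounds with values here, for compound 4 the step is expected to be a 1.8-fold higher number from compound 3 to compound 4 (0.26 log units; within the scatter), beside the earlier step of a 2.0-fold higher number from compound 1 to compound 2 (0.30 log units; within the scatter); this rests only on the one earlier instance of the change, which stayed within the scatter. Compound 4 is therefore estimated at 65000 nM, with a range from 25000 nM to 160000 nM.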

Compound 4, concentration for 50% growth inhibition: 1830 nM
For compound 4 the middle estimate is 36-fold (1.55 log units) above the measured one; measured number outside the range, below it.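

Placed on the core of compound 3, the change from 3-methoxyphenyl to 2-methoxyphenyl on the carbonyl carbon gives a 19-fold lower number from compound 3 to compound 4 (1.29 log units; beyond the scatter) in this assay, so the step did not carry over from the core of compound 1: the same change on two cores in this assay, a 2.0-fold higher number (0.30 log units; within the scatter) from compound 1 to compound 2 and a 19-fold lower number (1.29 log units; beyond the scatter) from compound 3 to compound 4, 39-fold (1.59 log units) apart, beyond the scatter of two such steps

Read the other way, the exchange of methyl for hydrogen on the oxygen gives an 8.4-fold lower number from compound 2 to compound 4 (0.92 log units; beyond the scatter), and it does not carry over from the 3-methoxyphenyl amide to the 2-methoxyphenyl amide either: the same change on two cores in this assay, a 4.6-fold higher number (0.67 log units; beyond the scatter) from compound 1 to compound 3 and an 8.4-fold lower number (0.92 log units; beyond the scatter) from compound 2 to compound 4, 39-fold (1.59 log units) apart, beyond the scatter of two such steps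

These four compounds thus show that, in this assay, the effect of each change depends on the other, so neither step can simply be transferred between these cores; but both comparisons rest on the same four compounds, forming a single case, and they do not show why the steps differ or whether the dependence extends to other members of the series.

The compounds shown leave open whether the gain seen for compound 4 is specific to the methoxy group or would also appear with a plain phenyl, an ethoxy group or a fluorine on the amide's aromatic ring. They also leave open whether an amine in place of the hydroxy group on the core would behave in the same way.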